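A Branch on the Chain: Compound 2 to Compound 3

This account rests on a few compounds, and the source may have more. Where it says the series, first, only, none or still open, it means among the compounds named here.

For the measured compounds named here, in an assay on H4 cells for inhibition of Fatty-acid amide hydrolase 1 (Homo sapiens) (on this read-out higher numbers stand for weaker inhibition and lower numbers for stronger inhibition), compound 2 `CCOC(=O)CC(C)CCCCCn1c(C)nc(-c2ccccc2)c1-c1ccccc1` gives 130 nM, the higher of the two numbers known so far. The nearest measured compound, compound 1 `CCOC(=O)CCCOc1ccc(-n2cnc(-c3ccccc3)c2-c2ccccc2)cc1`, gives 64 nM in this assay, a lower number by a gap beyond the usual scatter; the two differ in many places at once, so only their values can be compared. Compound 3 `CCOC(=O)CC(CC)CCCCCn1c(C)nc(-c2ccccc2)c1-c1ccccc1` differs from compound 2 in one place: methyl in place of hydrogen on a saturated chain carbon, three bonds along the chain from a carbonyl carbon. Going by the values given here, no measured pair shows such a change here, so the step of no change at the digits printed from compound 2 to compound 3 (within the scatter) is expected to stay within the scatter, with no clear direction. Compound 3 is estimated at 130 nM, between 60 nM and 300 nM.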

Compound 3, half-maximal inhibitory concentration: 9900 nM
Compound 3: the middle estimate sits 76-fold (1.88 log units) below what was measured, and the stated range ends below it.
By their numbers in this assay, from the lowest: compound 1; then compound 2; then compound 3.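

Methyl in place of hydrogen on a saturated chain carbon, three bonds along the chain from a carbonyl carbon, is the first single-place change in this series, and in this assay it gives a 76-fold higher number from compound 2 to compound 3 (1.88 log units; beyond the scatter) and so a large move toward weaker inhibition. At this position, then, methyl to ethyl on the branch is far from a neutral change. Nothing at hand explains the loss.

As far as these compounds go, whether a longer chain such as propyl on this carbon weakens inhibition further remains open, as does how a hydroxyl group there would compare with the ethyl of compound 3.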